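Hydroxyalkyl chain homologation: tolerated concentration notes

The source may report more compounds than this note shows. Statements on the series, on what has been measured and on what is new or still open speak of the compounds shown alone.

Measured so far in an ADME assay on HEp-2 cells (Homo sapiens) for cytotoxicity, with a stated time of 4 days; a lower number here means that less compound is tolerated, a higher number that more compound is tolerated:
- compound 1 `CS(=O)(=O)c1nn(Cc2nc3cc(Cl)ccc3n2CCO)c2cnccc12` gives > 100000 nM, a limit of this assay.
- compound 2 `CS(=O)(=O)c1nn(Cc2nc3cc(Cl)ccc3n2CCCO)c2cnccc12` gives > 100000 nM, a limit of this assay.

Compound 2 therefore stands only at a limit, with no number read; both values shown sit at the limit of > 100000 nM in this assay, at which 2 of the 2 values shown sit. For the measured compounds named here, the one measured step, a step that the two limits leave unreadable from compound 1 to compound 2, is unreadable in size because the limit of > 100000 nM in this assay, at which 2 of the 2 values shown sit, holds at both of its ends.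

Compound 3 `CS(=O)(=O)c1nn(Cc2nc3cc(Cl)ccc3n2CCCCO)c2cnccc12` carries the same chain extended once more: hydroxymethyl in place of hydroxy on a saturated chain carbon, three bonds along the chain from an aromatic nitrogen. Going by the values given here, the only step that bears on this change, from compound 1 to compound 2, shows no readable size, so nothing points to a shift beyond the scatter in this assay; the expectation is that compound 3 again reaches the limit.

For compound 3 the estimate in this assay is 150000 nM, with a range from 60000 nM to 400000 nM. The step that the limit leaves unreadable from compound 2 to compound 3 is expected to be none beyond the scatter.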

Compound 3, half-maximal cytotoxic concentration: > 100000 nM
Compound 3: a limit, no number; the forecaster's own chance of this, stated with the estimate: 85%; the middle value is on the limit's open side.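

No step among compound 1, compound 2 and compound 3 can be read, because all three values are limits: the limit of > 100000 nM in this assay, at which 3 of the 3 values shown sit.

The compounds shown leave open where the true tolerated concentrations lie in this assay, and whether the 2-hydroxyethyl, 3-hydroxypropyl and 4-hydroxybutyl chains differ at all.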